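A few compounds are considered here, and "the series" means these few. Any claim that something is new, unique, unknown or untested is made for them only; others in the source may bear on it.

Measured so far:
compound 1 `C=CCOc1ccc(C(=O)Nc2cccc(CC)n2)cc1`: 27400 nM
compound 2 `CCCCNc1cccc(NC(=O)c2ccc(OCCC)cc2)n1`: 77800 nM

Two compounds measured in an in vitro assay on HEK-tsA201 cells for antagonist activity at Neuronal acetylcholine receptor; alpha3/beta4 (Homo sapiens), read by fluorescence and calcium flux (a lower number here means a stronger inhibitor, a higher number a weaker inhibitor), so far. Compound 1 `C=CCOc1ccc(C(=O)Nc2cccc(CC)n2)cc1` gives 27400 nM, compound 2 `CCCCNc1cccc(NC(=O)c2ccc(OCCC)cc2)n1` gives 77800 nM. Compound 2 thus stands with the highest number of the two, and the gap to compound 1 lies beyond the scatter, so compound 2 is the weaker inhibitor of the pair. Among the measured compounds shown here, no step between these two is counted, since they differ in more than one place.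

Compound 3 `CCCOc1ccc(C(=O)Nc2cccc(Nc3ccc(OC)cc3)n2)cc1` has not yet been measured. Against compound 2 the difference is 4-methoxyphenyl in place of butyl on a nitrogen on an aromatic ring. For the measured compounds named here, no measured pair shows this change, so the direction and size of the step from compound 2 to compound 3 rest on no data from the series. A moderate change toward a lower number is expected, with wide uncertainty, and a limit rather than a number remains possible at this range. For compound 3 the expected value in this assay is 40000 nM, between 10000 nM and 150000 nM, meaning a step of a 1.9-fold lower number from compound 2 to compound 3 (0.29 log units; within the scatter) is estimated.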

Compound 3, half-maximal inhibitory concentration: > 100000 nM
Compound 3 was reported as a limit; the forecaster's own chance of this, stated with the estimate: 30%; middle value at least 2.5-fold (0.39 log units) away from the limit.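

In this assay compound 3 gives > 100000 nM, which is a limit of the assay and not a number. Among the compounds shown here, replacing butyl with 4-methoxyphenyl on the nitrogen on an aromatic ring gives an at least 1.2-fold higher number from compound 2 to compound 3 (0.10 log units; that floor lies within the scatter), the first reading of any change at this position, and it shows that this larger aromatic group yields no stronger inhibition than butyl. The result fixes only the direction of the comparison as far as the floor allows, and that floor does not separate the two compounds beyond the scatter: the limit of > 100000 nM in this assay, at which 1 of the 3 values shown sits.

As far as these compounds go, whether the phenyl ring or its methoxy group governs the result remains open, and an unsubstituted phenyl or a benzyl on this nitrogen would separate the two. From the compounds shown here alone, it also remains open whether a free amine or a shorter chain such as methyl at this place would give a lower number.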